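A few compounds are considered here, and "the series" means these few. Any claim that something is new, unique, unknown or untested is made for them only; others in the source may bear on it.

Measured in a functional assay on A2780 cells (Homo sapiens) for antiproliferative activity, read by MTT assay, with a stated time of 48 h; a lower number here means a stronger inhibitor, a higher number a weaker inhibitor:
- compound 1 `COc1ccc(C(=O)c2ccc3c(c2)C=CC(C)(C)O3)c(NC(=O)CN)c1` gives 590 nM
- compound 2 `CNCC(=O)Nc1cc(OC)ccc1C(=O)c1ccc(OC)c2c1C=CC(C)(C)O2` gives 1590 nM
- compound 3 `C=C(c1cc(OC)c(OC)c(OC)c1)c1ccc(OC)cc1NC(=O)CO` gives 30 nM

Compound 3 has the lowest number of the three, and both others lie beyond the scatter from it. Compound 4 `C=C(c1cc(OC)c(OC)c(OC)c1)c1ccc(OC)cc1NC(=O)CNCC` keeps the core of compound 3 and carries ethylamino in place of hydroxy on a saturated chain carbon bound to a carbonyl carbon. Going by the values given here, no measured pair isolates this change. Compound 1 at 590 nM and compound 2 at 1590 nM carry a nitrogen on that chain, on different cores, and this gives only weak support for expecting a higher number. A moderate upward step a 3.3-fold higher number from compound 3 to compound 4 (0.52 log units; beyond the scatter) is expected in this assay and would mean a weaker inhibitor. For compound 4 the estimate is 100 nM with an expected range from 25 nM to 450 nM in this assay.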

Compound 4, half-maximal inhibitory concentration: 450 nM
Compound 4: the middle estimate sits 4.5-fold (0.65 log units) below what was measured, and the stated range covers the measured number.
By their numbers in this assay, from the lowest: compound 3; then compounds 4 and 1 (each within the scatter of the next); then compound 2.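

In this assay, going by these compounds alone, ethylamino in place of hydroxy on a saturated chain carbon bound to a carbonyl carbon gives a 15-fold higher number from compound 3 to compound 4 (1.18 log units; beyond the scatter) on the shared core, the first reading of this change with all else held constant. The position is therefore sensitive to the group it carries, since the step is large although the counted hydrogen-bond donors and acceptors stay the same. Nothing measured here accounts for the size of this step.

Still open, as far as these compounds go, is how a dimethylamino group or a carboxylic acid at this place would read on this core. Also open, from the compounds shown here alone, is whether a longer chain would follow ethylamino or hydroxy.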